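Piperidinyl amide as the next step from the butyl amide

A few compounds are considered here, and "the series" means these few. Any claim that something is new, unique, unknown or untested is made for them only; others in the source may bear on it.

The series shares one core, seen in compound 1 `COc1cc2c(cc1OC)C(CC(N)=O)CC2`, which in a functional assay on the whole organism (strain Swiss albino) for inhibition, with Mus musculus as the target, in the writhing test, with stated times of 60 min and 15 min, at a dose of 100 mg/kg by the oral route (a lower number here means less inhibition, a higher number more inhibition at the dose given (going by the name of the read-out)), gives 24.6%. Compound 2 `CNC(=O)CC1CCc2cc(OC)c(OC)cc21` gives 21.2% in this assay, and compound 3 `CCCCNC(=O)CC1CCc2cc(OC)c(OC)cc21` gives 39.4%. Compound 3 therefore stands highest of the three, with compound 1 nearest and compound 2 furthest, both gaps beyond the scatter.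

Compound 4 `COc1cc2c(cc1OC)C(CC(=O)N1CCCCC1)CC2` follows from compound 3 by a change on the carbonyl carbon: piperidin-1-yl in place of butylamino on a carbonyl carbon.

All three measured steps concern substitution at the amide-type nitrogen. The step of a number 3.4 percentage points lower from compound 1 to compound 2 (within the scatter) stayed within the scatter, while a number 14.8 percentage points higher from compound 1 to compound 3 (beyond the scatter) and a number 18.2 percentage points higher from compound 2 to compound 3 (beyond the scatter) were modest rises. Going by the values given here, compound 4 keeps a nitrogen substituent of comparable size to butyl but in a ring and without the amide hydrogen, for which no measured step exists. He therefore expects a step of a number 4.4 percentage points lower from compound 3 to compound 4 (within the scatter) in this assay, not beyond the scatter. Compound 4 is estimated at 35%, within 20% to 50%.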

Compound 4, a percentage reported as inhibition, in the whole organism at one dose (the size of the read-out at that dose, not a potency): 44.7%
Estimate against measurement, compound 4: 9.7 percentage points below; the range from low to high includes it.
By their numbers in this assay, from the lowest: compounds 2 and 1 (each within the scatter of the next); then compounds 3 and 4 (each within the scatter of the next).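

In this assay, piperidin-1-yl in place of butylamino on the carbonyl carbon gives a number 5.3 percentage points higher from compound 3 to compound 4 (within the scatter), so compound 4, which lacks the amide hydrogen, cannot be told apart from compound 3. Set against the smaller groups, the same ring gives a number 23.5 percentage points higher from compound 2 to compound 4 (beyond the scatter) and a number 20.1 percentage points higher from compound 1 to compound 4 (beyond the scatter), which shows that an amide hydrogen is not required for the higher read-out seen with butylamino. Nothing available explains this result.

The compounds shown leave open whether the ring itself matters, which an open-chain diethylamino or dipropylamino group on the same carbonyl carbon could separate from the loss of the amide hydrogen. They also leave open whether a ring with a second hetero atom, such as morpholin-4-yl or piperazin-1-yl, would give a similar read-out.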